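From 1,3-thiazol-5-yl to 1,3-benzothiazol-2-yl on compound 3

The compounds below may be only part of what the source reports. "The series", "measured", "known", "first", "only" and "open" are said of these compounds alone.

In a toxicity assay on NIH3T3 cells (Mus musculus) for cytotoxicity, read by resazurin assay (on this read-out lower numbers stand for an effect already at smaller amounts and higher numbers for an effect only at larger amounts of compound), compound 3 (`Nc1cc(-c2ccccc2)ccc1Cn1cncc1CNc1ccc(-c2cncs2)c(-c2ccccc2)c1`) gives > 1000 nM as a limit, not a number. Compound 1 (`N#Cc1ccc(NCc2cncn2Cc2ccc(-c3ccccc3)cc2N)cc1-c1ccccc1`) gives > 1000 nM as a limit too. Compound 2 (`c1ccc(-c2ccc(Cn3cncc3CNc3ccc(-c4nc5ccccc5s4)c(-c4ccccc4)c3)cc2)cc1`), which also bears 1,3-benzothiazol-2-yl, likewise gives > 1000 nM as a limit. Compound 3 therefore has no exact position, and the picture so far is the limit of > 1000 nM in this assay, at which 3 of the 3 values shown sit, and nothing more.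

Compound 4 (`Nc1cc(-c2ccccc2)ccc1Cn1cncc1CNc1ccc(-c2nc3ccccc3s2)c(-c2ccccc2)c1`) carries 1,3-benzothiazol-2-yl in place of 1,3-thiazol-5-yl on an aromatic carbon, ortho to a phenyl group (1,3-benzothiazol-2-yl in place of 1,3-thiazol-5-yl on an aromatic carbon). Going by the values given here, the one measured step at this same place is a step that the two limits leave unreadable from compound 1 to compound 3 and so offers no size to carry forward. Among the compounds with values here, no measured step points in either direction for this change. In this assay the expectation is therefore no shift beyond the scatter, and the estimated move is a step that the limit leaves unreadable from compound 3 to compound 4 with another limit as the likeliest report. For compound 4 the estimate is 1500 nM with an expected range from 700 nM to 5000 nM as the likely span.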

Compound 4, half-maximal effective concentration: > 1000 nM
Compound 4 gave a limit, no number; the forecaster's own chance of this, stated with the estimate: 85%; the middle value does not contradict the limit.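

The steps linking compound 4 to compound 1, compound 2 and compound 3 in this assay cannot be read, since each of the four compounds gives only a limit and not a number: the limit of > 1000 nM in this assay, at which 4 of the 4 values shown sit. The compounds shown leave open where any of the four truly lies and whether any of these changes moves the read-out at all.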